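A few compounds are considered here, and "the series" means these few. Any claim that something is new, unique, unknown or untested is made for them only; others in the source may bear on it.

Measured so far in a functional assay on MCF7 cells (Homo sapiens) for inhibition, read by microscopy and colony formation, with a stated time of 10 days; on this read-out lower numbers stand for stronger inhibition and higher numbers for weaker inhibition:
- compound 1 `CCCCCCCCCCCCCCNC(=O)[C@H](CO)NC(=O)C1CCCCC1` gives 7200 nM
- compound 2 `CCCCCCCCCCCCCCNC(=O)[C@H](CO)NC(=O)C(C)(C)C` gives 6700 nM

Compound 2 stands level with compound 1, and the two cannot be told apart. Compound 3 `CCCCCCCCCCCCCCNC(=O)[C@H](CO)NC(=O)c1cc(OC)cc(OC)c1` has 3,5-dimethoxyphenyl in place of tert-butyl on a carbonyl carbon and is the next to be read. For the measured compounds named here, only one measured step bears on this, a 1.1-fold lower number from compound 1 to compound 2 (0.03 log units; within the scatter) as the sole evidence, and it brings in no aromatic ring, so guidance is weak. No step beyond the scatter is expected in this assay, though with wide margins. The expected change is a 1.1-fold lower number from compound 2 to compound 3 (0.05 log units; within the scatter) on this reasoning. For compound 3 the estimate is 6000 nM with an expected range from 2500 nM to 14000 nM in this read-out.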

Compound 3, half-maximal inhibitory concentration: 11200 nM
For compound 3 the middle estimate is 1.9-fold (0.27 log units) below the measured one, and the stated range covers the measured number.
By their numbers in this assay, from the lowest: compounds 2, 1 and 3 (each within the scatter of the next).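

Read in this assay the aromatic 3,5-dimethoxyphenyl group on the carbonyl carbon gives a 1.7-fold higher number from compound 2 to compound 3 (0.22 log units; within the scatter) and a 1.6-fold higher number from compound 1 to compound 3 (0.19 log units; within the scatter) and so stays level with both tert-butyl and cyclohexyl. At this position, a six-membered aromatic ring with two hydrogen-bond acceptors therefore gives no step beyond the scatter in this read-out. No evidence on hand bears on this result. Still open, from the compounds shown here alone, is whether a phenyl ring carrying an amine or a carboxylic acid in place of 3,5-dimethoxyphenyl would give a step beyond the scatter.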